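Methylsulfanyl for iodo: expectations for compound 3

This account rests on a few compounds, and the source may have more. Where it says the series, first, only, none or still open, it means among the compounds named here.

Measured in a functional assay on HFF cells (Homo sapiens) for cytotoxicity; on this read-out lower numbers stand for stronger inhibition and higher numbers for weaker inhibition:
- compound 1 `CC(=O)OC1C(CF)OC(n2c(Cl)nc3cc(Cl)c(Cl)cc32)C1OC(C)=O` gives 32000 nM
- compound 2 `CC(=O)OC1C(CI)OC(n2c(Cl)nc3cc(Cl)c(Cl)cc32)C1OC(C)=O` gives 32000 nM

Against compound 1, compound 2 stands level at 32000 nM. Compound 3 `CSCC1OC(n2c(Cl)nc3cc(Cl)c(Cl)cc32)C(OC(C)=O)C1OC(C)=O` has not yet been measured. Its difference from compound 2 is methylsulfanyl in place of iodo on a saturated chain carbon bound to a saturated ring carbon.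

Among the compounds with values here, one measured step bears on this change: no change at the digits printed from compound 1 to compound 2 (within the scatter), with iodo in place of fluoro on that same saturated chain carbon. Within the data shown here, no measured compound carries methylsulfanyl, so this single step is limited guidance. On the evidence of no change at the digits printed from compound 1 to compound 2 (within the scatter), no step beyond the scatter is expected in this assay, and neither direction is favoured. The expected step is a 1.1-fold lower number from compound 2 to compound 3 (0.03 log units; within the scatter). For compound 3 the estimated value is 30000 nM, with an expected range of 12000 nM to 70000 nM.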

Compound 3, half-maximal inhibitory concentration: 32000 nM
The estimate for compound 3 lay 1.1-fold (0.03 log units) below the measured number, within the range that was stated.
By their numbers in this assay, from the lowest: compounds 1, 2 and 3 (each within the scatter of the next).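

Working notes on the saturated chain carbon bound to a saturated ring carbon: in this assay, methylsulfanyl in place of iodo gives no change at the digits printed from compound 2 to compound 3 (within the scatter), and methylsulfanyl in place of fluoro gives no change at the digits printed from compound 1 to compound 3 (within the scatter). The earlier pair compared two halogens only, whereas this result extends the flat picture to a non-halogen group with two heavy atoms, one of them sulfur, and one hydrogen-bond acceptor, with compound 3 at 32000 nM. No evidence available here accounts for this lack of movement.

With all three compounds level, the series does not yet show that any group at this position can move the number in this assay. An amine, a carboxylic acid or a longer chain such as butylsulfanyl on that carbon remains an open test of how far this flat picture extends.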